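Lengthening the linker on a spiro-hydantoin cholesterol-transporter binder

A few compounds are considered here, and "the series" means these few. Any claim that something is new, unique, unknown or untested is made for them only; others in the source may bear on it.

Two close relatives sit side by side here. Compound 2 `CC(C)(C)OC(=O)NCNC(=O)CN1CN(c2ccccc2)C2(CCN(C(=O)c3ccc(C4CCCCC4)cc3)CC2)C1=O` carries a cyclohexyl-substituted benzoyl group and a short link between its two amide-type nitrogens. Compound 1 `CC(C)(C)OC(=O)NCCCCNC(=O)CN1CN(c2ccccc2)C2(CCN(C(=O)c3ccc(C(C)(C)C)cc3)CC2)C1=O` keeps the same core but has a tert-butyl group on the benzoyl ring and a longer link; for compound 1 the value in an assay on HEK293 cells for displacement of a labelled ligand from NPC1-like intracellular cholesterol transporter 1 (Homo sapiens) (on this read-out lower numbers stand for stronger inhibition and higher numbers for weaker inhibition), is given as "not determined" (no result reported), so it adds nothing to the numbers. In this assay compound 2 gives 1700 nM, the only number shown, and it therefore stands alone as the single reference point.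

Compound 3 `CC(C)(C)OC(=O)NCCCCNC(=O)CN1CN(c2ccccc2)C2(CCN(C(=O)c3ccc(C4CCCCC4)cc3)CC2)C1=O` is the untested blend of the two: the cyclohexyl benzoyl of compound 2 joined to the longer link of compound 1. Counted against compound 2 the change is 3-((tert-butoxycarbonyl)amino)propyl in place of (tert-butoxycarbonyl)amino on a saturated chain carbon bound to an amide-type nitrogen. Going by the values given here, no pair of measured compounds spans this change, so nothing measured says how the link length matters. A step of modest size in either direction, or none beyond the scatter, is the honest expectation, and the step from compound 2 to compound 3 is expected to be a 1.4-fold lower number from compound 2 to compound 3 (0.15 log units; within the scatter). Compound 3 is thus estimated at 1200 nM, within a range from 300 nM to 5000 nM.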

Compound 3, half-maximal inhibitory concentration: 4600 nM
Estimate against measurement, compound 3: 3.8-fold (0.58 log units) below; measured number inside the range.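

In this assay, going by these compounds alone, putting 3-((tert-butoxycarbonyl)amino)propyl in place of (tert-butoxycarbonyl)amino on a saturated chain carbon bound to an amide-type nitrogen gives a 2.7-fold higher number from compound 2 to compound 3 (0.43 log units; beyond the scatter) and thereby supplies the first comparison. It shows that this position responds to the change: the longer chain goes with weaker inhibition, while the counts of donors, acceptors, rings and charge stay the same and only the count of heavy atoms rises. No measurement shown explains why the longer chain weakens inhibition.

A single lengthening cannot show whether inhibition weakens steadily with each added carbon, whether a chain of intermediate length or a still longer chain would follow the same trend, or whether a free amine or a carboxylic acid at the chain end would respond differently. Going by these compounds, the step from compound 1 to compound 3 cannot be read, so the effect of tert-butyl against cyclohexyl on the benzoyl ring also remains open.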